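A few compounds are considered here, and "the series" means these few. Any claim that something is new, unique, unknown or untested is made for them only; others in the source may bear on it.

Compound 1 `CCCNC(=C\C(=O)/C=C/c1ccc(O)c(OC)c1)/C=C/c1ccc(O)c(OC)c1` gives 78% in a functional assay on EA.hy 926 cells (Homo sapiens), read by fluorescence, tested at 1 uM (a higher number here means a stronger effect of the compound at the concentration tested, a lower number a weaker effect), the lowest of the three numbers recorded. Compound 3 `CC(C)CNC(=C\C(=O)/C=C/c1ccc(O)cc1)/C=C/c1ccc(O)cc1` gives 100% in this assay, a number beyond the scatter above compound 1. Compound 2 `COc1cc(/C=C/C(=O)/C=C(/C=C/c2ccc(OC(C)=O)c(OC)c2)NCC(C)C)ccc1OC(C)=O` gives 104% in this assay, also beyond the scatter above compound 1. Compound 4 `COc1cc(/C=C/C(=O)/C=C(/C=C/c2ccc(O)c(OC)c2)NCC(C)C)ccc1O` is not yet measured; it differs from compound 1 by methyl in place of hydrogen on a saturated chain carbon bound to two saturated chain carbons. Both compounds carrying the isobutylamino group sit above compound 1 in this assay, so an upward step beyond the scatter is expected here, though the two ring substitution patterns of compound 4 match neither of them exactly. The expected step is a number 18 percentage points higher from compound 1 to compound 4 (beyond the scatter). Compound 4 is estimated at 96%, with a range from 80% to 110%.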

Compound 4, a percentage reported as activity, at one concentration (the size of the read-out at that concentration, not a potency): 83%
Estimate against measurement, compound 4: 13 percentage points above; the measured number falls inside the stated range.
By their numbers in this assay, from the lowest: compounds 1 and 4 (each within the scatter of the next); then compounds 3 and 2 (each within the scatter of the next).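

On the shared core, going from propylamino to isobutylamino gives a number 5 percentage points higher from compound 1 to compound 4 (within the scatter) in this assay, so methyl in place of hydrogen on this saturated chain carbon leaves the two compounds indistinguishable. Going by these compounds alone, this is the first pair isolating the chain, and the isobutylamino group alone does not account for the numbers of compound 2 and compound 3, which differ from compound 1 in more than one place. Nothing measured bears on this result. Going by these compounds, whether a longer chain such as hexyl, or a benzyl group, in place of isobutyl would shift the read-out remains open.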